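A few compounds are considered here, and "the series" means these few. Any claim that something is new, unique, unknown or untested is made for them only; others in the source may bear on it.

In an ADME assay on microsomes from liver (Rattus norvegicus) for metabolic stability, read by LC-MS, using NADPH, with a stated time of 30 min, tested at 0.1 uM (a lower number here means that less of the compound is left, a higher number that more of the compound is left), compound 1 (`O=S(=O)(NCC1COC1)c1cccc(-c2ccc3nccc(-c4ccncc4)c3n2)c1`) gives 8%. Compound 2 (`O=S(=O)(NCCN1CCCC1)c1cccc(-c2ccc3nccc(-c4ccnc(C(F)(F)F)c4)c3n2)c1`) gives 16%, which lies within the scatter of compound 1. Compound 3 (`O=S(=O)(CCO)c1cccc(-c2ccc3nccc(-c4ccncc4)c3n2)c1`) gives 59%, and the measured step is a number 51 percentage points higher from compound 1 to compound 3 (beyond the scatter).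

Compound 4 (`C[C@@H]1CN(S(=O)(=O)c2cccc(-c3ccc4nccc(-c5ccncc5)c4n3)c2)C[C@H](C)N1`) departs from compound 1 at the sulfonyl sulfur: 3,5-dimethylpiperazin-1-yl in place of ((oxetan-3-yl)methyl)amino on a sulfonyl sulfur.

Among the measured compounds shown here, only the step to compound 3 bears directly on this change, as it is the one measured step at the same place. For the measured compounds named here, it shows that replacing the group on the sulfonyl sulfur can shift this read-out by a large amount, but 2-hydroxyethyl is a different group, and no measured compound carries 3,5-dimethylpiperazin-1-yl. Compound 2 differs from compound 1 in more than one place, so compound 2 with 16% gives only a loose guide, and it stays close to compound 1. A modest change is therefore expected, with some room for a larger rise.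

The expected step is a number 9 percentage points higher from compound 1 to compound 4 (within the scatter).

For compound 4 the estimated value is 17%, with an expected range from 5% to 45%.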

Compound 4, percent of the compound remaining: 36%
The estimate for compound 4 lay 19 percentage points below the measured number; the measured number falls inside the stated range.
By their numbers in this assay, from the lowest: compounds 1 and 2 (each within the scatter of the next); then compound 4; then compound 3.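

In this assay the sulfonyl sulfur carries a second replacement that clearly lifts the read-out, with 3,5-dimethylpiperazin-1-yl giving (a number 28 percentage points higher from compound 1 to compound 4 (beyond the scatter)), although the counted hydrogen-bond donors and acceptors are the same in the group that leaves and the group that enters. The result also separates the two replacements at this place, as 3,5-dimethylpiperazin-1-yl stays clearly short of 2-hydroxyethyl (a number 23 percentage points lower from compound 3 to compound 4 (beyond the scatter)), so the size of the rise depends on the group chosen. No measurement at hand accounts for either step.

Going by these compounds, whether the two methyl groups or the defined stereocentres contribute remains open, and the plain piperazin-1-yl or a morpholin-4-yl ring on the sulfonyl sulfur would address this. On these data alone, a longer chain such as 3-hydroxypropyl on the same sulfur also remains open as a comparison with 2-hydroxyethyl.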